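Diene geometry and nitric oxide inhibition in a glycoside series

A few compounds are considered here, and "the series" means these few. Any claim that something is new, unique, unknown or untested is made for them only; others in the source may bear on it.

Measured compounds:
compound 1, `CCC/C=C/C=C\CCc1cc(O)c([C@@H]2O[C@H](CO)[C@@H](O)[C@H](O)[C@H]2O)c(O)c1C(=O)OC`: > 40000 nM
compound 2, `CCC/C=C\C=C\CCc1cc(O)c([C@@H]2O[C@H](CO)[C@@H](O)[C@H](O)[C@H]2O)c(O)c1C(=O)OC`: 14000 nM

In a functional assay on RAW264.7 cells (Mus musculus) for inhibition, read by Griess assay, with stated times of 2 h and 12 h (a lower number here means a stronger inhibitor, a higher number a weaker inhibitor), compound 2 gives 14000 nM, the only number shown in this set. In this assay compound 1 gives only a limit, > 40000 nM. The step of an at least 2.8-fold lower number from compound 1 to compound 2 (0.45 log units; beyond the scatter) rests on the limit of > 40000 nM in this assay, at which 1 of the 2 values shown sits, and on (the fact that compounds 1 and 2 differ only in the configuration as drawn), so its true size is not known beyond being at least modest.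

Compound 3, `CCC/C=C/C=C/CCc1cc(O)c([C@@H]2O[C@H](CO)[C@@H](O)[C@H](O)[C@H]2O)c(O)c1C(=O)OC`, differs from compound 2 in that (the two compounds have the same atoms and bonds and differ only in configuration as drawn: 1 of 7 stereo elements differ; a double bond is drawn Z in compound 2 and E in compound 3). Going by the values given here, the only measured step that bears on this change is an at least 2.8-fold lower number from compound 1 to compound 2 (0.45 log units; beyond the scatter), which also turned on the drawn configuration of a double bond, and it shows that such a change can move the number by at least a modest amount, in either direction for all that is known here. Compound 3 is therefore expected near 20000 nM, in the range 7000 nM to 60000 nM. The expected step of a 1.4-fold higher number from compound 2 to compound 3 (0.15 log units; within the scatter) is estimated to be small, within or just beyond the scatter, with a real chance that only a limit is reported.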

Compound 3, half-maximal inhibitory concentration: > 40000 nM
Compound 3: only a limit was reported (the forecaster's own chance of this, stated with the estimate: 35%); middle value at least 2.0-fold (0.30 log units) from the limit.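

The step of an at least 2.8-fold higher number from compound 2 to compound 3 (0.45 log units; beyond the scatter) in this assay shows that changing one double bond of the diene from Z to E can alone move the number beyond the scatter, whereas two double bonds changed together in the earlier step, and the ground for tying this step to that one bond is: the fact that compounds 2 and 3 differ only in the configuration as drawn Compound 3 gives only a limit, > 40000 nM, so the true size of this step is not known. Compounds 1 and 3 both stand at limits, so the step between them cannot be read, and of the three diene geometries shown only that of compound 2 gives a number.

Going by these compounds, whether that geometry keeps its number with a carboxylic acid in place of the methyl ester, or with a longer chain, remains open. Also open, on these data alone, is how a diene with both double bonds drawn Z would compare.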